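Exchanging one small ring group on a shared core

The source may hold more compounds than are shown below. What is called first, only, known or untested is meant among the compounds shown, and "the series" means these compounds.

In a functional assay on HeLa cells (Homo sapiens) for inhibition, with a stated time of 72 h (on this read-out lower numbers stand for stronger inhibition and higher numbers for weaker inhibition), compound 1 (`NC1CCC(Nc2nc(NCc3ccc(-c4ccccc4)nc3)c3ncn(C4CCCC4)c3n2)CC1`) gives 114 nM and compound 2 (`NC1CCC(Nc2nc(NCc3ccc(-c4cccs4)nc3)c3ncn(C4CCCC4)c3n2)CC1`) gives 40 nM while compound 3 (`NC1CCC(Nc2nc(NCc3cc(Cl)ccc3O)c3ncn(C4CCCC4)c3n2)CC1`) gives 750 nM as the highest number of the three, which makes it the weakest inhibitor so far. Compound 4 (`Nc1ccccc1CNc1nc(NC2CCC(N)CC2)nc2c1ncn2C1CCCC1`) has not yet been measured. It carries 2-aminophenyl in place of 5-chloro-2-hydroxyphenyl on a saturated chain carbon bound to a nitrogen on an aromatic ring.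

Among the compounds with values here, no measured step makes this exact exchange, so the evidence is indirect. At the same place, 5-chloro-2-hydroxyphenyl in place of 6-phenylpyridin-3-yl gave a modest step (a 6.6-fold higher number from compound 1 to compound 3 (0.82 log units; beyond the scatter)), and in place of 6-(thiophen-2-yl)pyridin-3-yl it gave a large one (a 19-fold higher number from compound 2 to compound 3 (1.27 log units; beyond the scatter)). These show that the group at this place matters. Exchanging one ring for another further out, thiophen-2-yl in place of phenyl, still gave a modest step (a 2.9-fold lower number from compound 1 to compound 2 (0.45 log units; beyond the scatter)), so a small exchange need not be silent. Both groups in the new exchange hold one six-membered aromatic ring of carbon only, and the data give no firm direction. The expected step in this assay is small (a 1.2-fold higher number from compound 3 to compound 4 (0.08 log units; within the scatter)) and would stay within the scatter. Compound 4 is estimated at 900 nM with an expected range from 250 nM to 3000 nM in this measurement.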

Compound 4, half-maximal inhibitory concentration: 1030 nM
Compound 4: middle estimate off by 1.1-fold (0.06 log units), on the low side; measured number inside the range.
By their numbers in this assay, from the lowest: compound 2; then compound 1; then compounds 3 and 4 (each within the scatter of the next).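

In this assay, 2-aminophenyl in place of 5-chloro-2-hydroxyphenyl gives a 1.4-fold higher number from compound 3 to compound 4 (0.14 log units; within the scatter), so at this place on the saturated chain carbon the two groups cannot be told apart, even though the chlorine and the hydroxyl are gone and an amino group has entered. The 2-aminophenyl group also stands well away from both groups with a pyridine ring, with a 9.0-fold higher number from compound 1 to compound 4 (0.96 log units; beyond the scatter) and a 26-fold higher number from compound 2 to compound 4 (1.41 log units; beyond the scatter): across these four compounds, the two groups with one six-membered aromatic ring of carbon only give higher numbers than 6-phenylpyridin-3-yl and 6-(thiophen-2-yl)pyridin-3-yl, and no compound shown goes against this. No measurement beyond these inhibition numbers is available to explain the result.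

From the compounds shown here alone, compounds 3 and 4 differ in more than one substituent on the ring, so what each substituent contributes on its own stays open, and a plain phenyl or a 2-hydroxyphenyl without the chlorine would be needed to separate them. Also open, going by these compounds, is whether the pyridine ring alone, as an unsubstituted pyridin-3-yl, would give a number nearer compound 1 or nearer compound 4.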